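Expected solubility of the difluorocyclohexyl analogue, compound 4

A few compounds are considered here, and "the series" means these few. Any claim that something is new, unique, unknown or untested is made for them only; others in the source may bear on it.

compound 1 `FC(F)(F)c1ccc(Nc2cc3[nH]c(C4CCOC4)nc3cn2)nc1` gives 180000 nM
compound 2 `FC(F)(F)c1ccc(Nc2cc3[nH]c(C4CCOCC4)nc3cn2)nc1` gives 168000 nM
compound 3 `FC(F)(F)c1ccc(Nc2cc3[nH]c(CC4CC4)nc3cn2)nc1` gives 156000 nM

In a physicochemical assay for solubility, using the shake flask method, in simulated intestinal fluid, measured as kinetic solubility, with a stated time of 20 h, at pH 6.5 (a higher number here means a more soluble compound, a lower number a less soluble compound), compound 3 stands at 156000 nM, within the scatter of both other compounds. The steps that reach it are a 1.2-fold lower number from compound 1 to compound 3 (0.06 log units; within the scatter) and a 1.1-fold lower number from compound 2 to compound 3 (0.03 log units; within the scatter), and the remaining pair shows a 1.1-fold lower number from compound 1 to compound 2 (0.03 log units; within the scatter). Exchanging these groups has so far moved this assay by nothing beyond the scatter.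

Compound 4 `FC1(F)CCC(c2nc3cnc(Nc4ccc(C(F)(F)F)cn4)cc3[nH]2)CC1` carries 4,4-difluorocyclohexyl in place of cyclopropylmethyl on an aromatic carbon, on the same core: 4,4-difluorocyclohexyl in place of cyclopropylmethyl on an aromatic carbon. The closest measured exchange is a 1.1-fold lower number from compound 2 to compound 3 (0.03 log units; within the scatter), which also involves a six-membered non-aromatic ring, and on its own it would point to no change. However, none of the three measured compounds has fluorine in this group, and the entering ring is of carbon only, so the data contain no direct precedent. A moderate fall in this assay is therefore expected, though with wide uncertainty that reaches back towards the measured compounds.

The expected step is a 2.2-fold lower number from compound 3 to compound 4 (0.35 log units; beyond the scatter). Compound 4 is estimated at 70000 nM, with an expected range of 20000 nM to 160000 nM.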

Compound 4, solubility: 93000 nM
Beside the measured number, compound 4's estimate is 1.3-fold (0.12 log units) below it; the range from low to high includes it.
By their numbers in this assay, from the lowest: compounds 4, 3, 2 and 1 (each within the scatter of the next).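

In this assay the step to the 4,4-difluorocyclohexyl group reads a 1.7-fold lower number from compound 3 to compound 4 (0.22 log units; within the scatter) and the same exchange read against the two oxygen-containing rings gives a 1.8-fold lower number from compound 2 to compound 4 (0.26 log units; within the scatter) and a 1.9-fold lower number from compound 1 to compound 4 (0.29 log units; within the scatter) so all three steps stay within the scatter. Going by these compounds alone, the position on an aromatic carbon of the five-membered aromatic ring therefore takes a group of 8 heavy atoms with 2 fluorine and a six-membered ring of carbon only without a step beyond the scatter, something the earlier compounds, none of which carried fluorine in this group, could not show. No available measurement bears on what lies behind these numbers.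

Compound 4 differs from compound 3 in ring size and in fluorine together, so the series shown cannot separate the two, and an unsubstituted cyclohexyl ring would be needed for that reading. As far as these compounds go, whether an amine, a carboxylic acid or a longer chain at this position would give a step beyond the scatter remains open.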